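Swapping bromo for iodo on the aryl urea of compound 2

A few compounds are considered here, and "the series" means these few. Any claim that something is new, unique, unknown or untested is made for them only; others in the source may bear on it.

Compound 2 `C[C@@H](NC(=O)Nc1cccc(Br)c1)c1ccccc1` is a small aryl urea carrying a bromo group on an aromatic carbon. Going by the values given here, in an ADME assay on the whole organism with Oryza sativa as the target, tested at 10 uM (a higher number here means a weaker effect of the compound at the concentration tested, a lower number a stronger effect), compound 2 gives 99%, the highest of the two numbers known here; its nearest neighbour is compound 1 `CC(=O)c1cccc(NC(=O)N[C@H](C)c2ccccc2)c1`, which in this assay gives 73%. Among the compounds with values here, the one step measured so far, a number 26 percentage points higher from compound 1 to compound 2 (beyond the scatter), is the only change at that aromatic carbon on record, and it concerned an acetyl group rather than a halogen.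

Compound 3 `C[C@@H](NC(=O)Nc1cccc(I)c1)c1ccccc1` differs from compound 2 in a single place: iodo in place of bromo on an aromatic carbon. Within the data shown here, no measured step describes a swap of one halogen for another at this position, so the expectation rests on the weak general resemblance of the two halogens and on the fact that compound 2 already sits near the top of the scale. The step is therefore expected to lie within the scatter, with a number 4 percentage points lower from compound 2 to compound 3 (within the scatter) as the estimated change.

For compound 3 the expected read-out in this assay is 95%, with a range from 82% to 100%.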

Compound 3, a percentage reported as activity, at one concentration (the size of the read-out at that concentration, not a potency): 73%
Compound 3: middle estimate off by 22 percentage points, on the high side; the whole stated range lies above it.
By their numbers in this assay, from the lowest: compounds 1 and 3 (each within the scatter of the next); then compound 2.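

In this assay, going by these compounds alone, exchanging one halogen for another at this aromatic carbon proves to be no neutral swap: iodo in place of bromo gives a number 26 percentage points lower from compound 2 to compound 3 (beyond the scatter) and matches in size the one step known before, so having a halogen at this place does not by itself set the read-out. Iodo in place of acetyl gives no change at the digits printed from compound 1 to compound 3 (within the scatter) and places two differently named groups level within the scatter, which leaves the bromo of compound 2 as the one group of the three set apart from both others. Nothing available accounts for this separation of bromo from iodo and acetyl.

Going by these compounds, it remains open whether chloro, fluoro, an amine or a carboxylic acid at this aromatic carbon would give a read-out with compound 2 or with compounds 1 and 3. It is equally open whether the gap between bromo and iodo would persist with a longer chain in place of the methyl group elsewhere on the shared core, since all three compounds shown differ only at this one aromatic carbon.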